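The compounds below may be only part of what the source reports. "The series", "measured", "known", "first", "only" and "open" are said of these compounds alone.

Measured compounds in a functional assay on RXF 393 cells (Homo sapiens) for inhibition, read by sulforhodamine B assay, with a stated time of 48 h; on this read-out higher numbers stand for lower toxicity in this test and lower numbers for higher toxicity in this test:
compound 1, `COc1cc(-c2nn(-c3cccc(NC(=O)Nc4cc(C(F)(F)F)cc(C(F)(F)F)c4)c3)cc2-c2ccncc2)ccc1Cl`, gives 4900 nM
compound 2, `O=C(Nc1cccc(-n2cc(-c3ccncc3)c(-c3ccc(Cl)c(O)c3)n2)c1)Nc1cc(C(F)(F)F)cc(C(F)(F)F)c1`, gives 10700 nM
compound 3, `COc1cc(-c2nn(-c3cccc(NC(=O)Nc4ccc(Cl)c(C(F)(F)F)c4)c3)cc2-c2ccncc2)ccc1Cl`, gives > 32500 nM, which is a limit of the assay and not a number.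

Compound 1 and compound 2 share one core. Compound 2 differs from compound 1 by hydrogen in place of methyl on an oxygen on an aromatic ring. In this assay this change produced a 2.2-fold higher number from compound 1 to compound 2 (0.34 log units; beyond the scatter), that is, a move toward lower toxicity.

Compound 3 carries a different core; the difference between the core of compound 1 and the core of compound 3 is not broken down here. For compound 3 the assay reports only (the limit of > 32500 nM in this assay, at which 1 of the 3 values shown sits).

Compound 4, `O=C(Nc1cccc(-n2cc(-c3ccncc3)c(-c3ccc(Cl)c(O)c3)n2)c1)Nc1ccc(Cl)c(C(F)(F)F)c1`, is not yet measured. It differs from compound 3 by hydrogen in place of methyl on an oxygen on an aromatic ring. The place of the change is described in exactly the same words as for the pair compound 1 to compound 2, so it is the same change, made on the other core.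

Within the data shown here, the only measured instance of this change, a 2.2-fold higher number from compound 1 to compound 2 (0.34 log units; beyond the scatter), pushed the number up by a modest amount. Compound 3 already sits at the limit, so the same direction of movement would keep compound 4 at or beyond that limit. Compound 4 is therefore expected to give 60000 nM in this assay. The expected step is a step that the limit leaves unreadable from compound 3 to compound 4, resting on a 2.2-fold higher number from compound 1 to compound 2 (0.34 log units; beyond the scatter) applied to the limit (the limit of > 32500 nM in this assay, at which 1 of the 3 values shown sits). The expected range for compound 4 runs from 25000 nM to 200000 nM, and the most likely outcome is that the assay again reports only a limit for compound 4.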

Compound 4, concentration lethal to 50% of the cells: > 32500 nM
Compound 4: a limit, no number; the forecaster's own chance of this, stated with the estimate: 80%; the middle value is on the limit's open side.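

In this assay compound 3 gives > 32500 nM as a limit of the assay and not a number. Among these compounds, compound 4 gives > 32500 nM as a limit too, so no step between compound 3 and compound 4 can be read. From the compounds shown here alone, it remains open whether methoxy to hydroxy on the core of compound 3 moves the number as in a 2.2-fold higher number from compound 1 to compound 2 (0.34 log units; beyond the scatter) on the core of compound 1.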